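Replacing an aromatic arm with a branched amine chain

This account rests on a few compounds, and the source may have more. Where it says the series, first, only, none or still open, it means among the compounds named here.

Compound 3 `NCc1cccc(CN(C[C@H]2Cc3ccccc3CN2)[C@H]2CCCc3cccnc32)c1` is measured in a functional assay on cells for agonist activity at C-X-C chemokine receptor type 4 (Homo sapiens), read by fluorescence and calcium flux, with a stated time of 90 s (on this read-out lower numbers stand for an effect already at smaller amounts and higher numbers for an effect only at larger amounts of compound), where compound 3 gives only a limit, > 30000 nM. Compound 1 `c1cncc(CNCCCCN(C[C@H]2Cc3ccccc3CN2)[C@H]2CCCc3cccnc32)c1` likewise reaches only the limit > 30000 nM in this assay. Compound 2 `c1ccc2c(c1)CN[C@@H](CN(CCCCNC1CCOCC1)[C@H]1CCCc3cccnc31)C2` in this assay also shows only the limit > 30000 nM. The steps a step that the two limits leave unreadable from compound 1 to compound 2, a step that the two limits leave unreadable from compound 1 to compound 3 and a step that the two limits leave unreadable from compound 2 to compound 3 stay unreadable because of the limit of > 30000 nM in this assay, at which 3 of the 3 values shown sit. Compound 4 `CC(C)(CCN)CN(C[C@H]1Cc2ccccc2CN1)[C@H]1CCCc2cccnc21` differs from compound 3 by a group of 6 heavy atoms (5 carbon, 1 nitrogen; no ring) in place of a group of 8 heavy atoms (7 carbon, 1 nitrogen; one six-membered aromatic ring of carbon only), on a saturated chain carbon bound to an amine nitrogen. Within the data shown here, no measured step gives a readable size for such a change. Compound 4 is expected to remain at or near the limit, with an estimated step that the limit leaves unreadable from compound 3 to compound 4. Compound 4 is therefore estimated at 40000 nM, with a range from 8000 nM to 200000 nM.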

Compound 4, half-maximal effective concentration in the C-X-C chemokine receptor type 4 assay: > 30000 nM
Compound 4 was reported as a limit (the forecaster's own chance of this, stated with the estimate: 80%); the middle value is on the limit's open side.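

In the C-X-C chemokine receptor type 4 assay compound 4 gives only a limit, > 30000 nM. Among these compounds, no step from compound 1, compound 2 or compound 3 to compound 4 can be read, because all four compounds give only a limit: the limit of > 30000 nM in the C-X-C chemokine receptor type 4 assay, at which 4 of the 4 values shown sit. The compounds shown leave open which group on the saturated chain carbon bound to an amine nitrogen, if any, would give a readable value in the C-X-C chemokine receptor type 4 assay. In a physicochemical assay for permeability, using PAMPA, with a stated time of 4 h, at pH 7.4, tested at 100 uM (on this read-out higher numbers stand for higher permeability and lower numbers for lower permeability), compound 3 is reported as "not determined" (no result reported). In the physicochemical assay compound 4 gives 255 nm/s. Compound 3 and compound 4 therefore cannot be compared on this read-out.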